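Flipping one stereocentre in a cytotoxicity series

The source may hold more compounds than are shown below. What is called first, only, known or untested is meant among the compounds shown, and "the series" means these compounds.

Measured compounds:
compound 1, `C=CCNC(=O)[C@@H](NC(=O)[C@@](O)(CCCN(Cc1ccc(Br)cc1)NC(=O)[C@@H](NC(=O)OC)C(C)(C)C)Cc1ccc(Br)cc1)C(C)C`: 22000 nM
compound 2, `C=CCNC(=O)[C@@H](NC(=O)[C@@](O)(CCCN(Cc1ccc(Br)cc1)NC(=O)[C@@H](NC(=O)OC)C(C)(C)C)Cc1ccc(C=C)cc1)C(C)(C)C`: 44000 nM
compound 3, `C=CCNC(=O)[C@@H](NC(=O)[C@@](O)(CCCN(Cc1ccc(Br)cc1)NC(=O)[C@@H](NC(=O)OC)C(C)(C)C)Cc1ccc(Br)cc1)C(C)(C)C`: 29000 nM

In an ADME assay on MT4 cells (Homo sapiens) for cytotoxicity, read by XTT assay, with a stated time of 5 days (a lower number here means that less compound is tolerated, a higher number that more compound is tolerated), compound 1 gives 22000 nM, compound 2 gives 44000 nM and compound 3 gives 29000 nM. Compound 3 thus sits with the second highest of the three numbers, and both of its neighbours lie within the scatter of it: the step of a 1.3-fold higher number from compound 1 to compound 3 (0.12 log units; within the scatter) and the step of a 1.5-fold lower number from compound 2 to compound 3 (0.18 log units; within the scatter) are each too small to count as a real change.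

Compound 4, `C=CCNC(=O)[C@@H](NC(=O)[C@](O)(CCCN(Cc1ccc(Br)cc1)NC(=O)[C@@H](NC(=O)OC)C(C)(C)C)Cc1ccc(Br)cc1)C(C)(C)C`, is not yet measured. Its difference from compound 3 is the two compounds have the same atoms and bonds and differ only in configuration as drawn: 1 of 3 stereo elements differ; a stereocentre at a saturated chain carbon is drawn R in compound 3 and S in compound 4, namely that a stereocentre at a saturated chain carbon is drawn R in compound 3 and S in compound 4, with the same atoms and bonds throughout.

For the measured compounds named here, none of the measured steps changes a configuration, so no step bears directly on this one. The two steps that exist, a methyl in place of hydrogen and a bromo in place of vinyl, both stayed within the scatter, and all three numbers cluster closely. On that basis the expected step of no change at the digits printed from compound 3 to compound 4 (within the scatter) is none beyond the scatter. Compound 4 is therefore estimated at 29000 nM in this assay, with a range from 12000 nM to 65000 nM.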

Compound 4, half-maximal cytotoxic concentration: 21000 nM
The estimate for compound 4 lay 1.4-fold (0.14 log units) above the measured number, within the range that was stated.
By their numbers in this assay, from the lowest: compounds 4, 1, 3 and 2 (each within the scatter of the next, the first and the last beyond it).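

In this assay, for the compounds shown here, the earlier steps swapped one group for another, whereas this is the first to alter a configuration, and it reads a 1.4-fold lower number from compound 3 to compound 4 (0.14 log units; within the scatter). At this saturated chain carbon, then, drawing the stereocentre R or S makes no difference that this measurement can separate from ordinary repeat-to-repeat variation, at least for this pair of compounds. The comparison is an unusually clean one, as nothing else in the structures can account for the small gap between the two numbers: the fact that compounds 3 and 4 differ only in the configuration as drawn

The compounds shown leave open whether the other two stereo elements are equally unimportant, since neither of them is flipped in any pair here, and whether this result would hold with other groups elsewhere in the molecule. An amine or a carboxylic acid in place of the bromo on an aromatic carbon, for instance, might or might not leave the two configurations just as hard to tell apart, and the present numbers say nothing about that.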